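Replacing the methoxypyridinyl arm with a methoxyethoxy chain

The source may report more compounds than this note shows. Statements on the series, on what has been measured and on what is new or still open speak of the compounds shown alone.

The series shares an acrylamide-bearing core, shown in compound 1 `C=CC(=O)Nc1cccc(Nc2ncnc(Nc3ccc(-c4ccc(C)nc4)cc3)n2)c1`, and was tested in a functional assay on Raji cells (Homo sapiens) for antiproliferative activity, read by CCK-8 assay, with a stated time of 24 h; on this read-out higher numbers stand for weaker inhibition and lower numbers for stronger inhibition. In this assay compound 1 gives 13800 nM. Compound 2 `C=CC(=O)Nc1cccc(Nc2ncnc(Nc3ccc(-c4ccc(OC)nc4)cc3)n2)c1` carries a methoxy group on its pyridine ring in place of the methyl group of compound 1, but for compound 2 this assay reports "not determined" (no result reported), so no number stands for it at present; the only anchor for the series is the weak result of compound 1.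

Compound 3 `C=CC(=O)Nc1cccc(Nc2ncnc(Nc3ccc(OCCOC)cc3)n2)c1` differs from compound 2 by one exchange: 2-methoxyethoxy in place of 6-methoxypyridin-3-yl on an aromatic carbon. The aromatic pendant is thus traded for a short flexible ether chain. Within the data shown here, with no value for compound 2 and no measured step among the compounds, the size and direction of the step from compound 2 to compound 3 in this assay cannot be read from the data; only compound 1 points to where the series sits. On that basis compound 3 is expected to remain a weak inhibitor, with an estimated value of 20000 nM in this assay, and a plausible range from 5000 nM to 80000 nM.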

Compound 3, half-maximal inhibitory concentration: 105000 nM
Estimate against measurement, compound 3: 5.3-fold (0.72 log units) below; measured number above the stated range.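

In this assay, among these compounds, the exchange of 6-methylpyridin-3-yl for 2-methoxyethoxy gives a 7.6-fold higher number from compound 1 to compound 3 (0.88 log units; beyond the scatter), the first measured step, and it lies beyond the usual scatter. This shows that the number responds to the group on this aromatic carbon, para to a large group, and that here the ring-free ether chain goes with weaker inhibition than the methylpyridinyl arm, although the step from compound 2 to compound 3 cannot be read, as compound 2 has no value. Nothing measured here bears on why the number rises.

A single pair cannot separate the loss of the aromatic ring from the arrival of the ether oxygens, and it cannot show whether a methoxy group on the pyridine ring would read differently from the methyl group of compound 1. The compounds shown also leave open how a longer chain, a morpholine or a carboxylic acid would read at this position, and whether any group here could bring the number well below that of compound 1.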